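Lengthening the sulfur chain beyond compound 3

The source may report more compounds than this note shows. Statements on the series, on what has been measured and on what is new or still open speak of the compounds shown alone.

In a functional assay on NALM-6 cells (Homo sapiens) (a higher number here means a weaker inhibitor, a lower number a stronger inhibitor), compound 1 (`CSC[C@H](NC(C)=O)C(=O)CCl`) gives 30300 nM and compound 2 (`CCSC[C@H](NC(C)=O)C(=O)CCl`) gives 52800 nM. That gap lies within the scatter (a 1.7-fold higher number from compound 1 to compound 2 (0.24 log units; within the scatter)). Compound 3 (`CCCCCSC[C@H](NC(C)=O)C(=O)CCl`) gives 5800 nM, the lowest number of the three. Compound 4 (`CCCCCCCCCSC[C@H](NC(C)=O)C(=O)CCl`) differs from it by one change (butyl in place of hydrogen on a saturated chain carbon, five bonds along the chain from a sulfur): butyl in place of hydrogen on a saturated chain carbon, five bonds along the chain from a sulfur. Among the measured compounds shown here, two measured steps bear on this (a 5.2-fold lower number from compound 1 to compound 3 (0.72 log units; beyond the scatter)) and (a 9.1-fold lower number from compound 2 to compound 3 (0.96 log units; beyond the scatter)), both modest and both toward lower numbers. Three compounds are thin support, so a further modest drop is only expected (a 3.2-fold lower number from compound 3 to compound 4 (0.51 log units; beyond the scatter)). Compound 4 is estimated at 1800 nM (estimated range 500 nM to 6500 nM).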

Compound 4, half-maximal inhibitory concentration: 7300 nM
Estimate against measurement, compound 4: 4.1-fold (0.61 log units) below; the measured number lies above the stated range.
By their numbers in this assay, from the lowest: compounds 3 and 4 (each within the scatter of the next); then compounds 1 and 2 (each within the scatter of the next).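

In this assay, butyl in place of hydrogen on a saturated chain carbon, five bonds along the chain from a sulfur, leaves the number within the scatter (a 1.3-fold higher number from compound 3 to compound 4 (0.10 log units; within the scatter)). The drop seen on going to compound 3 therefore does not continue with this extension, and compound 3 and compound 4 cannot be told apart. Nothing available explains this levelling.

On these data alone, it remains open whether a longer chain than that of compound 4 would move the number. Also open, as far as these compounds go, is whether an amine or a carboxylic acid at the chain end would do so.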